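The source may report more compounds than this note shows. Statements on the series, on what has been measured and on what is new or still open speak of the compounds shown alone.

Compound 1 `O=C(Nc1ccccc1)C1CCN(CC(O)COc2ccc(C(F)(F)F)cc2)CC1` — 3100 nM
Compound 2 `O=C(c1ccccc1)c1ccccc1OCC(O)CN1CCC(C(=O)Nc2ccccc2)CC1` — 4300 nM
Compound 3 `O=C1c2ccccc2CN1C1CCN(CC(O)COc2cccc(C(F)(F)F)c2)CC1` — 1200 nM

All three were tested in an assay on isolated protein for inhibition of sodium channel protein type 1 subunit alpha (Homo sapiens), read by patch clamp; a lower number here means a stronger inhibitor, a higher number a weaker inhibitor. Compound 3 gives the lowest number of the three, 1200 nM, and its gaps to compound 1 and to compound 2 both lie beyond the usual scatter, so on these numbers compound 3 is the strongest inhibitor of the set. Compound 1 gives 3100 nM and compound 2 gives 4300 nM; these two share the same aromatic amide end, while compound 3 carries a different core, so no single-point comparison between them is available.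

Compound 4 `COc1cccc(OCC(O)CN2CCC(N3Cc4ccccc4C3=O)CC2)c1` keeps the core of compound 3 and changes one substituent: methoxy in place of trifluoromethyl on an aromatic carbon. Among the compounds with values here, no pair of measured compounds differs by this change alone, so nothing in the data fixes its size or direction. On the evidence at hand, the expectation for compound 4 is a number close to that of compound 3 or slightly higher, a 1.7-fold higher number from compound 3 to compound 4 (0.22 log units; within the scatter), a step that would not exceed the scatter. For compound 4 in this assay the estimate is 2000 nM, with a range from 800 nM to 5000 nM.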

Compound 4, half-maximal inhibitory concentration: 3000 nM
Estimate against measurement, compound 4: 1.5-fold (0.18 log units) below; the range from low to high includes it.
By their numbers in this assay, from the lowest: compound 3; then compounds 4, 1 and 2 (each within the scatter of the next).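

Methoxy in place of trifluoromethyl on an aromatic carbon, meta to a large group, gives a 2.5-fold higher number from compound 3 to compound 4 (0.40 log units; beyond the scatter) in this assay, and this is the only step here in which a single place changes. It shows that this position is not indifferent to the group it carries: on this core, the compound with trifluoromethyl is the stronger inhibitor and the compound with methoxy the weaker, although the size of the step is modest. No measurement here speaks to the reason for this difference.

The compounds shown leave open whether trifluoromethyl stands out at this position or methoxy simply falls short, and a chlorine atom, a nitrile or a plain hydrogen in the same place on the core of compound 3 would help to separate those two readings. Also open is whether the step carries over to another core, since compound 1 bears trifluoromethyl on a different core and has no methoxy partner among the compounds shown.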